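Acetyl for acetamido on the side chain of compound 1

The source may report more compounds than this note shows. Statements on the series, on what has been measured and on what is new or still open speak of the compounds shown alone.

In a functional assay on the whole organism for inhibition, with Cavia porcellus as the target (on this read-out higher numbers stand for an effect only at larger amounts of compound and lower numbers for an effect already at smaller amounts), compound 1 `COc1ccccc1OCC1SCCN1C(=O)CNC(C)=O` gives 40 mg/kg and compound 2 `COc1ccc(OCC2SCCN2C(=O)Cn2ccnc2)cc1` gives 48 mg/kg as its nearest value. These two numbers lie within the scatter of each other, so neither stands apart. Compound 3 `COc1ccccc1OCC1SCCN1C(=O)CC(C)=O` keeps the core of compound 1 and has acetyl in place of acetamido on a saturated chain carbon bound to a carbonyl carbon, counted as acetyl in place of acetamido on a saturated chain carbon bound to a carbonyl carbon in full. Going by the values given here, no measured pair shows this change. The expectation therefore rests on compound 1 at 40 mg/kg as its only anchor. In this assay the expected step of a 1.3-fold higher number from compound 1 to compound 3 (0.10 log units; within the scatter) stays within the scatter, with a slightly higher number the likelier direction. For compound 3 the estimated value is 50 mg/kg, with an expected range from 20 mg/kg to 120 mg/kg as the working bounds.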

Compound 3, dose for half-maximal effect: 30 mg/kg
Compound 3: the middle estimate sits 1.7-fold (0.22 log units) above what was measured, within the range that was stated.
By their numbers in this assay, from the lowest: compounds 3, 1 and 2 (each within the scatter of the next).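

On a saturated chain carbon bound to a carbonyl carbon, acetyl in place of acetamido gives a 1.3-fold lower number from compound 1 to compound 3 (0.12 log units; within the scatter) in this assay on the core of compound 1. Going by these compounds alone, this is the first direct step at this position, and it shows that the exchange, which removes the one hydrogen-bond donor counted on acetamido and its nitrogen, leaves the dose within the scatter. Nothing on hand explains why the two groups read alike and this single step gives no trend at this position.

Going by these compounds, whether an amine, a carboxylic acid or a longer chain in this place would move the number beyond the scatter in this assay stays open. Also open, on these data alone, is whether the same exchange would read alike with the other side of the molecule as in compound 2.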